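This account rests on a few compounds, and the source may have more. Where it says the series, first, only, none or still open, it means among the compounds named here.

Measured compounds:
compound 1 `COc1ccc(C)cc1N1C(=O)CSC1c1cccc(C(=O)NCCCCc2ccccc2)c1` — 300 nM
compound 2 `O=C(NCCCCn1cccn1)c1cccc(C2SCC(=O)N2c2cc(Br)ccn2)c1` — 105 nM
compound 3 `COc1ccccc1N1C(=O)CSC1c1cccc(C(=O)NCCCCn2cccn2)c1` — 91.7 nM

In a functional assay on HOS-TE85 cells (Homo sapiens) for inhibition, read by CCK-8 assay, with a stated time of 72 h (a lower number here means a stronger inhibitor, a higher number a weaker inhibitor), compound 1 gives the highest of the three numbers; compound 2 and compound 3 both sit beyond the scatter below it. Compound 4 `O=C(NCCCCc1ccccc1)c1cccc(C2SCC(=O)N2c2ccccc2F)c1` is not yet measured. Its difference from compound 1 is 2-fluorophenyl in place of 2-methoxy-5-methylphenyl on an amide-type nitrogen in a ring. Among the compounds with values here, the only measured step at the same place is a 1.1-fold lower number from compound 2 to compound 3 (0.06 log units; within the scatter), an exchange of aryl groups on the ring nitrogen that stayed within the scatter, although those two compounds carry a pyrazole-type side chain rather than the phenylbutyl chain of compound 1. That single step suggests the aryl swap from compound 1 to compound 4 should also leave the number close to its starting point, with no clear direction; the estimated step is a 1.1-fold lower number from compound 1 to compound 4 (0.03 log units; within the scatter). Compound 4 is therefore expected to give about 280 nM, within a range of 110 nM to 700 nM.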

Compound 4, half-maximal inhibitory concentration: 34.1 nM
Estimate against measurement, compound 4: 8.2-fold (0.91 log units) above, outside the stated range (below it).
By their numbers in this assay, from the lowest: compound 4; then compounds 3 and 2 (each within the scatter of the next); then compound 1.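

At the amide-type nitrogen in a ring, the choice of aryl group can matter a great deal in this assay, with 2-fluorophenyl in place of 2-methoxy-5-methylphenyl giving an 8.8-fold lower number from compound 1 to compound 4 (0.94 log units; beyond the scatter) on the phenylbutyl chain. The earlier exchange at this place, made on the pyrazole-type side chain, had shown only a 1.1-fold lower number from compound 2 to compound 3 (0.06 log units; within the scatter) and gave no sign of such a step. No measurement shown explains the change.

From the compounds shown here alone, whether a 2-chlorophenyl or an unsubstituted phenyl group on the phenylbutyl chain would stay nearer compound 1 or compound 4 remains open. So does whether 2-fluorophenyl would give a similar step on the pyrazole-type side chain.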